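Acetoxythiophene in Place of Halophenyl on the Urea

This account rests on a few compounds, and the source may have more. Where it says the series, first, only, none or still open, it means among the compounds named here.

Among the measured compounds shown here, compound 2 `O=C(Nc1ccc(Oc2ccc(-c3ncc[nH]3)cc2)cc1)Nc1ccc(F)c(Cl)c1` gives 4.2% in a functional assay on MDA-MB-231 cells (Homo sapiens) for inhibition, read by MTT assay and WST assay, with a stated time of 72 h, tested at 10 uM (a lower number here means less inhibition of growth, a higher number more inhibition of growth at the concentration tested), the smaller of the two numbers known, though its gap to compound 1 `O=C(Nc1ccccc1)Nc1ccc(Oc2ccc(-c3ncc[nH]3)cc2)cc1` at 11.4% sits within the scatter. For the measured compounds named here, the single measured step, a number 7.2 percentage points lower from compound 1 to compound 2 (within the scatter), also stayed within the scatter. Compound 3 `CC(=O)Oc1sccc1NC(=O)Nc1ccc(Oc2ccc(-c3ncc[nH]3)cc2)cc1` carries 2-acetoxythiophen-3-yl in place of 3-chloro-4-fluorophenyl on an amide-type nitrogen. This change sits at the same nitrogen as the measured step, which barely moved, so no shift beyond the scatter is expected in this assay. Compound 3 is therefore expected to give 8%, within 0% to 20%, an expected step of a number 3.8 percentage points higher from compound 2 to compound 3 (within the scatter).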

Compound 3, percent growth inhibition at one concentration: -1.46%
Compound 3: middle estimate off by 9.5 percentage points, on the high side; the measured number lies below the stated range.
By their numbers in this assay, from the lowest: compounds 3, 2 and 1 (each within the scatter of the next, the first and the last beyond it).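

Among the compounds shown here, at the amide-type nitrogen, 2-acetoxythiophen-3-yl in place of phenyl gives the first step beyond the scatter at this place (a number 12.9 percentage points lower from compound 1 to compound 3 (beyond the scatter)), a modest one. In place of 3-chloro-4-fluorophenyl, the same group gives a step that stays within the scatter (a number 5.7 percentage points lower from compound 2 to compound 3 (within the scatter)), so in this assay compound 3 separates only from compound 1. No evidence bearing on the cause of either step is available. Going by these compounds, whether an amine or a carboxylic acid in place of the acetoxy group would change the reading remains open. So does whether any group at this nitrogen can give more growth inhibition than phenyl.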